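Trading the Oxime for a Benzoyl Group on the Sulfur Chain

The source may hold more compounds than are shown below. What is called first, only, known or untested is meant among the compounds shown, and "the series" means these compounds.

Of the compounds shown here, three sharing one core have been measured in a functional assay on the whole organism (strain albino) for inhibition, with Rattus norvegicus as the target, read by paw edema, with a stated time of 3 h, at a dose of 0.28 mmol/kg by the oral route; on this read-out higher numbers stand for more inhibition at the one dose given (going by the name of the read-out) and lower numbers for less inhibition. Compound 1 `CCn1c(SCC(=O)c2ccccc2)nnc1-c1cc(OC)c(OC)c(OC)c1` gives 49%. Compound 2 `C=CCn1c(SC/C(=N/O)c2ccccc2)nnc1-c1cc(OC)c(OC)c(OC)c1` gives 70%, and compound 3 `COc1cc(-c2nnc(SC/C(=N/O)c3ccccc3)n2-c2ccccc2)cc(OC)c1OC` gives 64%, the second highest of the three, close to compound 2 and well above compound 1. Among the compounds with values here, the only single-place step measured, a number 6 percentage points lower from compound 2 to compound 3 (within the scatter), changes the group on the ring nitrogen, not the sulfur chain, so it does not bear directly on the next change. Compound 4 `COc1cc(-c2nnc(SCC(=O)c3ccccc3)n2-c2ccccc2)cc(OC)c1OC` differs from compound 3 by a group of 8 heavy atoms (7 carbon, 1 oxygen; one six-membered aromatic ring of carbon only) in place of a group of 9 heavy atoms (7 carbon, 1 nitrogen, 1 oxygen; one six-membered aromatic ring of carbon only), on a saturated chain carbon bound to a sulfur. Compound 1 carries the same benzoyl group and sits lowest, though it also differs at the nitrogen. A modest drop is therefore expected, a number 12 percentage points lower from compound 3 to compound 4 (beyond the scatter), giving compound 4 an estimated 52% with a range from 38% to 66% in this assay.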

Compound 4, a percentage reported as inhibition, in the whole organism at one dose (the size of the read-out at that dose, not a potency): 68%
Compound 4: the middle estimate sits 16 percentage points below what was measured; the measured number lies above the stated range.
By their numbers in this assay, from the lowest: compound 1; then compounds 3, 4 and 2 (each within the scatter of the next).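

On the saturated chain carbon bound to a sulfur, with phenyl on the ring nitrogen, benzoyl and the group it replaces read alike in this assay, with a number 4 percentage points higher from compound 3 to compound 4 (within the scatter). Benzoyl on this chain therefore does not go with a low number by itself: holding it fixed, phenyl in place of ethyl on the aromatic nitrogen gives a number 19 percentage points higher from compound 1 to compound 4 (beyond the scatter). Nothing measured here gives a reason for either step. Still open, as far as these compounds go, is whether the two chains also read alike with allyl or ethyl on that nitrogen, and what an amine or a carboxylic acid in place of benzoyl would give.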